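The compounds below may be only part of what the source reports. "The series", "measured", "known", "first", "only" and "open" are said of these compounds alone.

For the measured compounds named here, in a physicochemical assay for permeability (a higher number here means that the compound crosses the layer faster, a lower number that the compound crosses the layer more slowly), compound 1 `Brc1ccc(NC2=NCCC3(CCCCC3)S2)cc1` gives 90.3 10^-6 cm/s, the higher of the two numbers measured so far. The other measured compound, compound 2 `Fc1ccc(NC2=NCCC3(CCCCC3)S2)cc1Cl`, gives in this assay 7.36 10^-6 cm/s, a lower number, and the gap between the two lies beyond the scatter of repeated measurements. Compound 3 `Nc1ccc(NC2=NCCC3(CCCCC3)S2)cc1` has not yet been measured in this assay. It differs from compound 1 in one place: amino in place of bromo on an aromatic carbon. Bromo leaves and amino enters on an aromatic carbon of the six-membered aromatic ring of carbon only, para to a large group; where the departing group carried no hydrogen-bond donor and no hydrogen-bond acceptor, the entering group brings one of each. Going by the values given here, no step between two measured compounds matches this change, so the expectation rests on compound 1 alone and on the swap itself. A downward step in this assay is expected, larger than the scatter, of the size a 4.5-fold lower number from compound 1 to compound 3 (0.65 log units; beyond the scatter). For compound 3 the estimated value in this assay is 20 10^-6 cm/s, with a range from 5 10^-6 cm/s to 60 10^-6 cm/s.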

Compound 3, apparent permeability: 2.04 10^-6 cm/s
Compound 3: middle estimate off by 9.8-fold (0.99 log units), on the high side; measured number outside the range, below it.
By their numbers in this assay, from the lowest: compound 3; then compound 2; then compound 1.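

In this assay, the exchange of bromo for amino on an aromatic carbon, para to a large group, now has a measured size: a 44-fold lower number from compound 1 to compound 3 (1.65 log units; beyond the scatter), a large step and the first one in this set between compounds that differ in one place. It shows that this position is not indifferent to what it carries, as a group with no hydrogen-bond donor and no hydrogen-bond acceptor gives way to one with one of each while the rest of compound 1 stays the same, and the number falls well beyond the scatter. Nothing measured here gives a reason for the size of this step.

The compounds shown leave open whether a step of this kind belongs to the amino group in particular, or whether a hydroxyl, a methoxy or an acetamido group on the same carbon would give a similar number, and whether a chloro or a methyl group there would stay close to compound 1. They also leave open whether the same exchange would give a similar step on another aromatic carbon of the ring, as this single pair is all that speaks to it.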